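A few compounds are considered here, and "the series" means these few. Any claim that something is new, unique, unknown or untested is made for them only; others in the source may bear on it.

Working notes on the series. The shared core carries a variable group on a carbonyl carbon attached to an amide-type nitrogen in a ring. Compound 1, `Cc1nc(S(C)(=O)=O)ccc1Oc1ncnc(OC2CCN(C(=O)OC3COC3)CC2)c1F`, gives 66% in a functional assay on isolated protein for inhibition of Glucose-dependent insulinotropic receptor (Rattus norvegicus), read by HTRF and cAMP accumulation; on this read-out higher numbers stand for larger maximal responses and lower numbers for smaller maximal responses. Compound 2, `Cc1nc(S(C)(=O)=O)ccc1Oc1ncnc(OC2CCN(C(=O)OC3(C(F)(F)F)COC3)CC2)c1F`, gives 84% in this assay. Compound 3, `Cc1nc(S(C)(=O)=O)ccc1Oc1ncnc(OC2CCN(C(=O)SC(C)(C)C)CC2)c1F`, gives 76% in this assay, the second highest of the three numbers; its gaps to compound 2 and to compound 1 both lie within the scatter.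

The next compound, compound 4, `CCc1cnc(C(=O)N2CCC(Oc3ncnc(Oc4ccc(S(C)(=O)=O)nc4C)c3F)CC2)nc1`, differs from compound 3 only at that carbonyl carbon: 5-ethylpyrimidin-2-yl in place of (tert-butyl)sulfanyl on a carbonyl carbon. Of the measured steps, the two on the carbonyl carbon bear on this change: a number 10 percentage points higher from compound 1 to compound 3 (within the scatter) and a number 8 percentage points lower from compound 2 to compound 3 (within the scatter), both within the scatter. Among the compounds with values here, the one step beyond the scatter, a number 18 percentage points higher from compound 1 to compound 2 (beyond the scatter), concerns a trifluoromethyl on a saturated ring carbon and does not bear on it. Within the data shown here, no measured step brings in an aromatic ring at this position, so the expectation rests on the two small steps. For compound 4 a step of no change at the digits printed from compound 3 to compound 4 (within the scatter) in this assay is expected, within the scatter. The estimate for compound 4 is 76%, between 60% and 92%.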

Compound 4, largest response reached (reported as efficacy), in percent of the reference or control that the assay uses: 80%
Compound 4: the middle estimate sits 4 percentage points below what was measured; the measured number falls inside the stated range.
By their numbers in this assay, from the lowest: compounds 1, 3, 4 and 2 (each within the scatter of the next, the first and the last beyond it).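

At the carbonyl carbon, the first aromatic ring seen here, 5-ethylpyrimidin-2-yl, gives a number in this assay that lies within the scatter of both the open-chain (tert-butyl)sulfanyl group (a number 4 percentage points higher from compound 3 to compound 4 (within the scatter)) and the (3-(trifluoromethyl)oxetan-3-yl)oxy group (a number 4 percentage points lower from compound 2 to compound 4 (within the scatter)). Within the data shown here, its replacement of (oxetan-3-yl)oxy (a number 14 percentage points higher from compound 1 to compound 4 (beyond the scatter)) is the first exchange of the whole group on this carbon to fall beyond the scatter, although the step is modest. Nothing at hand accounts for these steps.

As far as these compounds go, it remains open how much of this result belongs to the ethyl group: a pyrimidin-2-yl without it, or a longer chain in its place, would test that in this assay. A phenyl ring or an amine on the carbonyl carbon would show whether the pyrimidine ring itself and the carbon link to it matter.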